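A few compounds are considered here, and "the series" means these few. Any claim that something is new, unique, unknown or untested is made for them only; others in the source may bear on it.

Measured compounds:

Compound 1 `Cc1cn2c(-c3cn[nH]c3)cnc2c(Nc2cc(Cn3cccc3)ns2)n1` — "not determined" (no result reported)
Compound 2 `Cc1cn2c(-c3cn[nH]c3)cnc2c(Nc2cc(Cc3ccccn3)ns2)n1` — 6880 ng.h/mL
Compound 3 `Cc1cn2c(-c3cn[nH]c3)cnc2c(Nc2cc(Cc3cccnc3)ns2)n1` — "not determined" (no result reported)

Three compounds share one core and differ only in the ring hung from the methylene on the aminothiazole side. Of the three, only compound 2 carries a number in an ADME assay on the whole organism for pharmacokinetics, with Rattus norvegicus as the target, with a stated time of 6 h, at a dose of 10 mg/kg by the oral route; a lower number here means less compound in the circulation, a higher number more compound in the circulation at the dose given; for compound 1 and compound 3 no result was reported, so compound 2 stands alone and nothing can be said about the effect of swapping one attached ring for another.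

Compound 4 `Cc1cn2c(-c3cn[nH]c3)cnc2c(Nc2cc(Cc3cccc(C(=O)N4CCCCC4)n3)ns2)n1` grows out of compound 2 by a single change: (piperidin-1-yl)carbonyl in place of hydrogen on an aromatic carbon. Going by the values given here, no pair of measured compounds shows what such an addition does to exposure, so the expectation rests on the size of the change alone. Going by these compounds, a large added group often shifts exposure, but the direction here is unknown, and the step of a 1.5-fold lower number from compound 2 to compound 4 (0.18 log units; within the scatter) is expected to stay within the usual scatter. For compound 4 the estimated exposure is 4500 ng.h/mL, with a range from 1200 ng.h/mL to 14000 ng.h/mL.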

Compound 4, area under the concentration-time curve: 50 ng.h/mL
Compound 4: the middle estimate sits 90-fold (1.95 log units) above what was measured, outside the stated range (below it).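

In this assay, placing (piperidin-1-yl)carbonyl on an aromatic carbon of the six-membered aromatic ring with 1 nitrogen, next to the ring nitrogen, gives a 140-fold lower number from compound 2 to compound 4 (2.14 log units; beyond the scatter), a step far beyond the scatter. Going by these compounds alone, this is the only reading of a change on this ring, and it shows that the position is not indifferent to what it carries: this single added group leaves far less compound in the circulation at the same dose. Nothing at hand says why the number falls so sharply.

Open, going by these compounds, is whether the drop follows from the whole group, from its six-membered non-aromatic ring or from the carbonyl alone. A methyl group, a simple primary amide or a carboxylic acid at the same carbon would help separate these possibilities.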